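This account rests on a few compounds, and the source may have more. Where it says the series, first, only, none or still open, it means among the compounds named here.

Three compounds share a core built from a fused two-ring system bearing a ketone, and they differ only in the group hanging from that core. Compound 1 `COc1ccc(-c2c(C(=O)c3cc(OC)c(OC)c(OC)c3)sc3ccccc23)cc1` gives 4200 nM in a functional assay on HeLa cells (Homo sapiens) for antiproliferative activity, read by MTT assay, with a stated time of 72 h; on this read-out higher numbers stand for weaker inhibition and lower numbers for stronger inhibition. Compound 2 `COc1cc(C(=O)c2sc3ccccc3c2-c2ccc(SC)cc2)cc(OC)c1OC` gives 3500 nM in the same assay, and compound 3 `COc1ccccc1-c1c(C(=O)c2cc(OC)c(OC)c(OC)c2)sc2ccccc12` gives 5000 nM. Compound 3 has the highest of the three numbers, but none of the gaps among them counts for anything: there is a 1.2-fold lower number from compound 1 to compound 2 (0.08 log units; within the scatter), a 1.2-fold higher number from compound 1 to compound 3 (0.08 log units; within the scatter), and a 1.4-fold higher number from compound 2 to compound 3 (0.15 log units; within the scatter), every one of them inside the scatter of repeated measurements.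

Compound 4 `COc1cc(C(=O)c2sc3ccccc3c2Nc2ccccc2)cc(OC)c1OC` is the next step from compound 3, and the change is anilino in place of 2-methoxyphenyl on an aromatic carbon. Each of the three measured steps was a swap of one aromatic group for another at this same place, and all of them left the number where it was. For the measured compounds named here, none of them tells how an anilino group will behave, since this is the first time that group appears; what they do show is that this position has so far accepted change without moving the number. The expectation is therefore a step no larger than the scatter, a 1.3-fold lower number from compound 3 to compound 4 (0.10 log units; within the scatter), with a wide band on either side. Compound 4 is estimated at 4000 nM, within a range from 1000 nM to 16000 nM.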

Compound 4, half-maximal inhibitory concentration: 2700 nM
The estimate for compound 4 lay 1.5-fold (0.17 log units) above the measured number, within the range that was stated.
By their numbers in this assay, from the lowest: compounds 4, 2, 1 and 3 (each within the scatter of the next).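

Anilino is the first group here that carries a hydrogen-bond donor, which 2-methoxyphenyl does not, and it brings a nitrogen to this place on the five-membered ring. Even so, in this assay the result is a 1.9-fold lower number from compound 3 to compound 4 (0.27 log units; within the scatter), a 1.3-fold lower number from compound 2 to compound 4 (0.11 log units; within the scatter) and a 1.6-fold lower number from compound 1 to compound 4 (0.19 log units; within the scatter), and since all three steps lie within the scatter, this change cannot be said to have moved the number. The position therefore accepts more than swaps of one directly attached methoxy- or methylsulfanyl-bearing aromatic group for another, although nothing available explains why the number holds steady under this change.

Every group shown at this place still contains a six-membered aromatic ring, so it remains open whether a simple amine, a carboxylic acid or a longer alkyl chain, none of which has that ring, would leave the number where it is. From the compounds shown here alone, it is also open whether the amine hydrogen of anilino plays any part, a question that an N-methylanilino group at the same place could address.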